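A few compounds are considered here, and "the series" means these few. Any claim that something is new, unique, unknown or untested is made for them only; others in the source may bear on it.

Of the compounds shown here, three that share one core have been tested in a functional assay on Ehrlich cells (Mus musculus) for cytotoxicity, read by MTT assay, with a stated time of 24 h; on this read-out lower numbers stand for stronger inhibition and higher numbers for weaker inhibition. Compound 1 `Cn1nc(-c2nnc(SCc3c(F)cccc3F)o2)cc1-c1ccc(C(F)(F)F)cc1` gives 28200 nM. Compound 2 `Cn1nc(-c2nnc(SCCOc3ccccc3F)o2)cc1-c1ccc(C(F)(F)F)cc1` gives 25200 nM, the smallest of the three numbers, although its steps to both other compounds fall within the scatter. Compound 3 `Cn1nc(-c2nnc(SCc3ccc(Cl)c(Cl)c3)o2)cc1-c1ccc(C(F)(F)F)cc1` gives 46200 nM. Every difference among these three sits on a saturated chain carbon bound to a sulfur: a 1.1-fold lower number from compound 1 to compound 2 (0.05 log units; within the scatter), a 1.6-fold higher number from compound 1 to compound 3 (0.21 log units; within the scatter) and a 1.8-fold higher number from compound 2 to compound 3 (0.26 log units; within the scatter), none of them beyond the scatter.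

Compound 4 `Cn1nc(-c2nnc(SCc3ccc(Cl)cc3F)o2)cc1-c1ccc(C(F)(F)F)cc1` has not yet been measured in this assay. It differs from compound 2 in one place: 4-chloro-2-fluorophenyl in place of (2-fluorophenoxy)methyl on a saturated chain carbon bound to a sulfur. The measured steps that bear on this are those at the same place, from compound 1 to compound 2 and from compound 2 to compound 3, and both stayed within the scatter, so a swap of this kind has so far moved the number very little. No step beyond the scatter is expected here either. Compound 4 is therefore estimated to give 30000 nM in this assay, with a range from 15000 nM to 60000 nM. The expected change amounts to a 1.2-fold higher number from compound 2 to compound 4 (0.08 log units; within the scatter).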

Compound 4, half-maximal inhibitory concentration: 26200 nM
The estimate for compound 4 lay 1.1-fold (0.06 log units) above the measured number; measured number inside the range.
By their numbers in this assay, from the lowest: compounds 2, 4, 1 and 3 (each within the scatter of the next).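

In this assay, the new group on a saturated chain carbon bound to a sulfur gives three steps that all stay within the scatter: a 1.0-fold higher number from compound 2 to compound 4 (0.02 log units; within the scatter), a 1.1-fold lower number from compound 1 to compound 4 (0.03 log units; within the scatter) and a 1.8-fold lower number from compound 3 to compound 4 (0.25 log units; within the scatter). This adds two things: replacing 2-(2-fluorophenoxy)ethyl, with its oxygen, by 4-chloro-2-fluorobenzyl does not move the number beyond the scatter, and neither does a ring carrying one fluorine and one chlorine, so all four groups now lie within the scatter of one another. Nothing at hand explains this flat picture.

As far as these compounds go, all four groups carry a halogen-bearing phenyl ring, so it remains open whether an amine, a carboxylic acid or a plain alkyl chain at this place would move the number beyond the scatter. From the compounds shown here alone, every compound also keeps the same core, and whether a change there would do more is equally open.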